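A few compounds are considered here, and "the series" means these few. Any claim that something is new, unique, unknown or untested is made for them only; others in the source may bear on it.

Measured in an ADME assay on Raji cells (Homo sapiens) for cytotoxicity, with a stated time of 72 h; on this read-out lower numbers stand for an effect already at smaller amounts and higher numbers for an effect only at larger amounts of compound:
- Compound 1 `CC(=O)c1ccc(NC(=O)Nc2cc(C)nc3ccccc23)cc1`: > 25000 nM, a limit.
- Compound 2 `Cc1cc(NC(=O)Nc2ccc(N(C)C)cc2)c2ccccc2n1`: > 25000 nM, a limit.
- Compound 3 `Cc1cc(NC(=O)Nc2ccc(C(F)(F)F)cc2)c2ccccc2n1`: 23000 nM.

Compound 3 is the only one of the three with an actual number. The other two stand at the limit of > 25000 nM in this assay, at which 2 of the 3 values shown sit.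

Compound 4 `Cc1cc(NC(=O)Nc2ccc(SC(F)(F)F)cc2)c2ccccc2n1` carries (trifluoromethyl)sulfanyl in place of trifluoromethyl on an aromatic carbon, para to a large group: (trifluoromethyl)sulfanyl in place of trifluoromethyl on an aromatic carbon.

Going by the values given here, no measured step covers this exchange directly. The nearest are the two other exchanges at the same place: an at least 1.0-fold lower number from compound 1 to compound 3 (0.03 log units; that floor lies within the scatter) and an at least 1.0-fold lower number from compound 2 to compound 3 (0.03 log units; that floor lies within the scatter). Both are floors only and lie within the scatter, while a step that the two limits leave unreadable from compound 1 to compound 2 cannot be read. These steps offer no ground for expecting a large shift, so no change beyond the scatter is expected in this assay. The expected step is a 1.3-fold lower number from compound 3 to compound 4 (0.11 log units; within the scatter).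

For compound 4 the estimated value is 18000 nM, with an expected range from 7000 nM to 30000 nM.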

Compound 4, half-maximal effective concentration: 10000 nM
Compound 4: the middle estimate sits 1.8-fold (0.26 log units) above what was measured; low and high end bracket the measured number.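

In this assay, going by these compounds alone, the earlier exchanges at this place, on an aromatic carbon para to a large group, gave only floors within the scatter, whereas (trifluoromethyl)sulfanyl in place of trifluoromethyl gives a 2.3-fold lower number from compound 3 to compound 4 (0.36 log units; beyond the scatter), the only step here with a readable size. Against the other two groups the same entering group gives an at least 2.5-fold lower number from compound 2 to compound 4 (0.39 log units; beyond the scatter) and an at least 2.5-fold lower number from compound 1 to compound 4 (0.39 log units; beyond the scatter), so this position can shift the read-out beyond the scatter. Those two steps remain floors because compound 1 and compound 2 each stay at a limit: the limit of > 25000 nM in this assay, at which 2 of the 4 values shown sit.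

With one sulfur-bearing group in the set, the shown compounds cannot separate the part played by the sulfur from that of the added atom count. Going by these compounds, whether a carboxylic acid, a primary amine or a longer chain such as pentafluoroethyl at this place would move the number further also stays open.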